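Series notes: aryl swap on the amide-type nitrogen

This account rests on a few compounds, and the source may have more. Where it says the series, first, only, none or still open, it means among the compounds named here.

Measured so far:
compound 1, `COc1cc(NC(=O)Nc2cc(Nc3cccc(C(C)(C)C)c3)ncn2)cc(OC)c1`: 13.1%
compound 2, `COc1cc(NC(=O)Nc2cc(Nc3ccc(F)c(Cl)c3)ncn2)cc(OC)c1`: 25.5%

In a functional assay on NCI-H520 cells (Homo sapiens) for inhibition, read by MTT assay, with a stated time of 48 h, tested at 10 uM (on this read-out lower numbers stand for less inhibition and higher numbers for more inhibition at the one concentration tested (going by the name of the read-out)), compound 1 gives 13.1%, the lowest of the two numbers; its nearest neighbour is compound 2 with 25.5%, and a number 12.4 percentage points higher from compound 1 to compound 2 (beyond the scatter).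

Compound 3, `CC(C)(C)c1cccc(Nc2cc(NC(=O)Nc3c(Cl)cccc3Cl)ncn2)c1`, differs from compound 1 by 2,6-dichlorophenyl in place of 3,5-dimethoxyphenyl on an amide-type nitrogen. Going by the values given here, the one measured step, from compound 1 to compound 2, alters the group on a nitrogen on an aromatic ring, not the amide-type nitrogen, so no step bears on this change directly. With nothing to go on, a step in this assay of no more than the scatter is expected, in either direction. For compound 3 the estimate is 18% (range 2% to 40%), that is an expected a number 4.9 percentage points higher from compound 1 to compound 3 (within the scatter).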

Compound 3, a percentage reported as inhibition, at one concentration (the size of the read-out at that concentration, not a potency): 29.6%
For compound 3 the middle estimate is 11.6 percentage points below the measured one, within the range that was stated.
By their numbers in this assay, from the lowest: compound 1; then compounds 2 and 3 (each within the scatter of the next).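

In this assay, the aryl group on the amide-type nitrogen, held constant in the earlier pair, also affects the read-out: 2,6-dichlorophenyl in place of 3,5-dimethoxyphenyl gives a number 16.5 percentage points higher from compound 1 to compound 3 (beyond the scatter). The read-out is therefore higher, not lower, with both methoxy groups gone and two chlorines entered. No available measurement accounts for this step.

Going by these compounds, it remains open whether one chlorine alone would give the same read-out, and how an amine or a carboxylic acid on this ring would behave. On these data alone, whether the step carries over to the 3-chloro-4-fluorophenyl compounds is also open.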